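The compounds below may be only part of what the source reports. "The series", "measured", "known", "first", "only" and "open" are said of these compounds alone.

Measured so far:
- compound 1 `CC(=O)N1CC2CC(C1)N2` gives 750 nM
- compound 2 `CCC(=O)N1CC2CC(C1)N2` gives 180 nM
- compound 3 `CCCC(=O)N1CC2CC(C1)N2` gives 300 nM

These three share one core and differ only in the chain on the carbonyl carbon. In an assay on CHO cells for agonist activity at Neuronal acetylcholine receptor; alpha3/alpha6/beta2/beta3 (Homo sapiens), read by FLIPR and calcium flux (a lower number here means that less compound is needed, a higher number that more compound is needed for the effect), compound 3 stands second of the three numbers: its nearest neighbour is compound 2, and the gap a 1.7-fold higher number from compound 2 to compound 3 (0.22 log units; within the scatter) lies within the scatter, while against compound 1 the step of a 2.5-fold lower number from compound 1 to compound 3 (0.40 log units; beyond the scatter) lies beyond it. Compound 4 `O=C(CC1C=CCC1)N1CC2CC(C1)N2` carries the change (cyclopent-2-en-1-yl in place of ethyl on a saturated chain carbon bound to a carbonyl carbon).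

Within the data shown here, three measured steps bear on this position. Lengthening the chain by one carbon gave a 4.2-fold lower number from compound 1 to compound 2 (0.62 log units; beyond the scatter), lengthening it by two gave a 2.5-fold lower number from compound 1 to compound 3 (0.40 log units; beyond the scatter), and the further step from one to two carbons gave a 1.7-fold higher number from compound 2 to compound 3 (0.22 log units; within the scatter). Beyond hydrogen, methyl and ethyl the data say nothing, and no ring has been tried at this place. Growth in this assay has so far paid off once and then levelled off, so a much larger group is expected to bring no gain and possibly a modest loss in this assay. For compound 4 the expected step is a 1.7-fold higher number from compound 3 to compound 4 (0.22 log units; within the scatter), giving an estimate of 500 nM with a range from 150 nM to 2000 nM.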

Compound 4, half-maximal effective concentration: 21000 nM
Estimate against measurement, compound 4: 42-fold (1.62 log units) below; measured number above the stated range.
By their numbers in this assay, from the lowest: compounds 2 and 3 (each within the scatter of the next); then compound 1; then compound 4.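

In this assay, the place on a saturated chain carbon bound to a carbonyl carbon proves far less forgiving than the small steps among hydrogen, methyl and ethyl suggested: cyclopent-2-en-1-yl in place of ethyl gave a 70-fold higher number from compound 3 to compound 4 (1.85 log units; beyond the scatter). Among these compounds, the change also does more than cancel the earlier gain, since the same group in place of methyl gave a 120-fold higher number from compound 2 to compound 4 (2.07 log units; beyond the scatter) and in place of hydrogen gave a 28-fold higher number from compound 1 to compound 4 (1.45 log units; beyond the scatter), so compound 4 falls well behind even the compound with neither methyl nor ethyl at this place, and all three steps are much larger than any seen among the earlier compounds. Nothing in the data shown explains why this change costs so much.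

The compounds shown leave open whether the loss goes with the ring, with its double bond, or with the larger number of carbons, as a saturated cyclopentyl group and an open butyl or pentyl chain would tell apart. They also leave open where between ethyl and cyclopent-2-en-1-yl the loss sets in, and whether a smaller ring such as cyclopropyl, or a chain ending in an amine or a hydroxyl group, would be accepted at this place.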